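Swapping the aminocyclohexyl ring for an open chain

The source may hold more compounds than are shown below. What is called first, only, known or untested is meant among the compounds shown, and "the series" means these compounds.

Measured so far in an ADME assay on microsomes from liver (Rattus norvegicus) for metabolic stability; on this read-out lower numbers stand for a less stable compound and higher numbers for a more stable compound:
compound 1 `N[C@H]1CC[C@H](CN(C[C@H]2Cc3ccccc3CN2)[C@H]2CCCc3cccnc32)CC1`: 51%
compound 2 `C/C(=C/CN)CN(C[C@H]1Cc2ccccc2CN1)[C@H]1CCCc2cccnc21`: 2%
compound 3 `N[C@H]1CC[C@H](N(C[C@H]2Cc3ccccc3CN2)[C@H]2CCCc3cccnc32)CC1`: 71%

Compound 3 stands highest of the three in this assay. Its nearest neighbour is compound 1, reached by a number 20 percentage points higher from compound 1 to compound 3 (beyond the scatter), and its furthest is compound 2, reached by a number 69 percentage points higher from compound 2 to compound 3 (beyond the scatter). Compound 4 `C/C(=C/CN(C[C@H]1Cc2ccccc2CN1)[C@H]1CCCc2cccnc21)CN` has not yet been measured in this assay. Relative to compound 3 it carries a group of 6 heavy atoms (5 carbon, 1 nitrogen; no ring) in place of a group of 7 heavy atoms (6 carbon, 1 nitrogen; one six-membered non-aromatic ring of carbon only), on an amine nitrogen.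

For the measured compounds named here, two measured steps bear on this change. The step from compound 2 to compound 3 is of the same kind run in the opposite direction, and it was large: a number 69 percentage points higher from compound 2 to compound 3 (beyond the scatter). The step from compound 1 to compound 2 likewise exchanged the ring-bearing group for an open chain and was also large: a number 49 percentage points lower from compound 1 to compound 2 (beyond the scatter). On that basis a large fall in this assay is expected, so that compound 4 is estimated at a number 61 percentage points lower from compound 3 to compound 4 (beyond the scatter). Compound 4 is therefore expected to give about 10% in this assay, with a likely range from 2% to 30%.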

Compound 4, percent of the compound remaining: 1%
Estimate against measurement, compound 4: 9 percentage points above, and the stated range ends above it.
By their numbers in this assay, from the lowest: compounds 4 and 2 (each within the scatter of the next); then compound 1; then compound 3.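

In this assay, the open chain now also fails when it sits directly on the amine nitrogen, the place held by the 4-aminocyclohexyl group in compound 3 (a number 70 percentage points lower from compound 3 to compound 4 (beyond the scatter)). The open chain in this place gives a result that cannot be told apart from the differently arranged open chain seen earlier (a number 1 percentage points lower from compound 2 to compound 4 (within the scatter)), so within these two chains, the arrangement of the chain and its double bond shows no measurable effect on the percent remaining. The ring-bearing group with the extra linking carbon also stands well clear of this new chain (a number 50 percentage points lower from compound 1 to compound 4 (beyond the scatter)), and across the compounds shown, both ring-bearing compounds hold up and both open-chain compounds do not, with none going against that pattern.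

Still open, as far as these compounds go, is whether the low numbers go with the missing ring or with the double bond, a question that a saturated aminobutyl chain on the same amine nitrogen would help to separate. Nothing available here explains why the open chains fare so poorly in this read-out.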